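This account rests on a few compounds, and the source may have more. Where it says the series, first, only, none or still open, it means among the compounds named here.

Compounds measured so far:
- compound 1, `CC(C)(C)C/N=C(\NC#N)Nc1ccncc1`, 5 mg/kg
- compound 2, `CC(C)CC(C)/N=C(\NC#N)Nc1ccncc1`, 35 mg/kg
- compound 3, `CC(/N=C(\NC#N)Nc1ccncc1)C1CC1`, 3 mg/kg

All three share one core and differ only in the group on the double-bonded nitrogen. In a functional assay on the whole organism (blood, strain Wistar-Okamoto) with Rattus norvegicus as the target, with a stated time of 5 days (on this read-out lower numbers stand for an effect already at smaller amounts and higher numbers for an effect only at larger amounts of compound), compound 2 stands at the highest number of the three: compared with compound 1 it shows a 7.0-fold higher number from compound 1 to compound 2 (0.85 log units; beyond the scatter), and going on to compound 3 gives a 12-fold lower number from compound 2 to compound 3 (1.07 log units; beyond the scatter). The step from compound 1 to compound 3 is a 1.7-fold lower number from compound 1 to compound 3 (0.22 log units; within the scatter).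

Compound 4, `CC(C)CC(C)(C)/N=C(\NC#N)Nc1ccncc1`, has not yet been measured. It differs from compound 2 by methyl in place of hydrogen on a saturated chain carbon bound to a double-bonded nitrogen and two saturated chain carbons. Going by the values given here, no measured step adds a methyl at this place, so the closest guide is indirect: the group of compound 1, which carries more branching near the nitrogen, sits at a lower number than compound 2, as a 7.0-fold higher number from compound 1 to compound 2 (0.85 log units; beyond the scatter) shows. On that basis a modest step downward is expected for compound 4, estimated at a 2.3-fold lower number from compound 2 to compound 4 (0.37 log units; beyond the scatter) in this assay. For compound 4 the estimated value is 15 mg/kg, with a likely range from 5 mg/kg to 50 mg/kg.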

Compound 4, minimum effective dose: 20 mg/kg
Compound 4: the middle estimate sits 1.3-fold (0.12 log units) below what was measured; low and high end bracket the measured number.
By their numbers in this assay, from the lowest: compounds 3 and 1 (each within the scatter of the next); then compounds 4 and 2 (each within the scatter of the next).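

In this assay, methyl in place of hydrogen on this saturated chain carbon gives a 1.8-fold lower number from compound 2 to compound 4 (0.24 log units; within the scatter), so this one added carbon does not separate the two compounds. The earlier steps shown here exchanged whole groups on the double-bonded nitrogen, whereas this one changes only this carbon and leaves the isobutyl part of the chain in place; that part is what cyclopropyl replaced in the large step, a 12-fold lower number from compound 2 to compound 3 (1.07 log units; beyond the scatter). Nothing in the data offered speaks to why the methyl leaves the number within the scatter.

Still open, from the compounds shown here alone, is whether an ethyl or an amine at this carbon would take the number beyond the scatter. Also open, going by these compounds, is whether the same methyl would have a larger effect on compound 3, which carries cyclopropyl instead of isobutyl.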